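A few compounds are considered here, and "the series" means these few. Any claim that something is new, unique, unknown or untested is made for them only; others in the source may bear on it.

Working notes on the series. In a functional assay (muscle tissue) with Rattus norvegicus as the target (on this read-out lower numbers stand for an effect already at smaller amounts and higher numbers for an effect only at larger amounts of compound), compound 1 (`CNC(=O)C1=CC(C)(C)Oc2ccc(C#N)cc21`) gives 263 nM and compound 2 (`CC1(C)C=C(C(=O)NC2CC2)c2cc([N+](=O)[O-])ccc2O1`) gives 32.4 nM as the lower of the two numbers, a gap beyond the scatter. These two compounds differ in more than one place, so no single change can be read from them. Going by the values given here, compound 3 (`CC1(C)C=C(C(N)=O)c2cc([N+](=O)[O-])ccc2O1`) carries hydrogen in place of cyclopropyl on an amide-type nitrogen and no measured step covers this change. The estimated shift in this assay is a 3.7-fold higher number from compound 2 to compound 3 (0.57 log units; beyond the scatter) towards a higher number, beyond the scatter. For compound 3 the expected value is 120 nM with an estimated range from 30 nM to 500 nM on this read-out.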

Compound 3, half-maximal effective concentration: 363 nM
Compound 3: the middle estimate sits 3.0-fold (0.48 log units) below what was measured; low and high end bracket the measured number.
By their numbers in this assay, from the lowest: compound 2; then compounds 1 and 3 (each within the scatter of the next).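

Going by these compounds alone, replacing cyclopropyl with hydrogen on the amide-type nitrogen gives, in this assay, an 11-fold higher number from compound 2 to compound 3 (1.05 log units; beyond the scatter), the first reading of a single change. The substituent on this nitrogen therefore matters on this read-out, and the cyclopropylcarbamoyl form holds the lower number against the plain carbamoyl form. No evidence on the cause of this step is available.

Going by these compounds, whether cyclopropyl is specifically required remains open: an ethyl, isopropyl or cyclobutyl group on this nitrogen could show that. Compound 1 cannot settle this, as it differs from compound 2 in more than one place.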